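Aryl exchange from compound 2 to compound 3

The source may report more compounds than this note shows. Statements on the series, on what has been measured and on what is new or still open speak of the compounds shown alone.

In an ADME assay on J774.A1 cells (Mus musculus) for cytotoxicity, read by MTT assay, with a stated time of 48 h (on this read-out lower numbers stand for higher toxicity in this test and higher numbers for lower toxicity in this test), compound 2 `COC(=O)c1c(NCCCCNc2ccnc3cc(Cl)ccc23)noc1-c1ccc([N+](=O)[O-])cc1` gives 136000 nM, which lies within the scatter of compound 1 `COc1ccc(CNC(=O)c2c([N+](=O)[O-])noc2-c2ccc(Cl)cc2Cl)cc1` at 80500 nM. Compound 3 `COC(=O)c1c(NCCCCNc2ccnc3cc(Cl)ccc23)noc1-c1ccc(Cl)cc1Cl` differs from compound 2 by 2,4-dichlorophenyl in place of 4-nitrophenyl on an aromatic carbon. Going by the values given here, no measured pair isolates this exchange, so its size is unknown. Compound 1 also carries 2,4-dichlorophenyl and gives 80500 nM, so only a small downward shift, not clearly beyond the scatter, is expected in this assay. The expected change is a 1.5-fold lower number from compound 2 to compound 3 (0.18 log units; within the scatter). For compound 3 the estimated value is 90000 nM, with an expected range of 35000 nM to 200000 nM.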

Compound 3, half-maximal cytotoxic concentration: 93600 nM
Compound 3: middle estimate off by 1.0-fold (0.02 log units), on the low side, and the stated range covers the measured number.
By their numbers in this assay, from the lowest: compounds 1, 3 and 2 (each within the scatter of the next).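

In this assay, going by these compounds alone, the exchange of 4-nitrophenyl for 2,4-dichlorophenyl on this aromatic carbon gives a 1.5-fold lower number from compound 2 to compound 3 (0.16 log units; within the scatter) and so provides the first matched reading at this position. On this single pair, the aryl exchange does not move the number beyond the scatter. No measured evidence bears on this step.

Open at this position is the effect of an unsubstituted phenyl or of a phenyl carrying an amine. Also open, going by these compounds, is the effect of a carboxylic acid in place of the methoxycarbonyl group.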